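The compounds below may be only part of what the source reports. "The series", "measured", "known", "first", "only" and "open" are said of these compounds alone.

Measured so far:
compound 1 `CCCCCCCCCCCC(=O)OCCc1ccc(O)cc1`: 67200 nM
compound 2 `CCCCCCCCCCCC(=O)OCCc1ccc(O)c(O)c1`: 38100 nM
compound 3 `O=C(O)[C@H]1O[C@@H](Oc2ccc(CCO)cc2)[C@H](O)[C@@H](O)[C@@H]1O`: 110000 nM

In a toxicity assay on MRC5 cells (Homo sapiens) for inhibition, read by MTT assay, with a stated time of 72 h (a lower number here means a stronger inhibitor, a higher number a weaker inhibitor), compound 1 stands second highest of the three numbers; its nearest neighbour is compound 3 and its furthest is compound 2, and both gaps lie within the scatter. Going by the values given here, the only single-point step measured, a 1.8-fold lower number from compound 1 to compound 2 (0.25 log units; within the scatter), concerns a hydroxy group and stays within the scatter.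

Compound 4 `CCCCCCCCCC(=O)OCCc1ccc(O)cc1` differs from compound 1 by hydrogen in place of ethyl on a saturated chain carbon, nine bonds along the chain from a carbonyl carbon. Among the compounds with values here, no measured step touches this chain, so there is no direct guide. Within the data shown here, with the one measured step so small, the expectation for compound 4 in this assay is a step of a 1.1-fold higher number from compound 1 to compound 4 (0.05 log units; within the scatter), none beyond the scatter. Compound 4 is therefore estimated at 75000 nM, with a range from 35000 nM to 160000 nM.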

Compound 4, half-maximal inhibitory concentration: 172000 nM
For compound 4 the middle estimate is 2.3-fold (0.36 log units) below the measured one; measured number above the stated range.
By their numbers in this assay, from the lowest: compounds 2, 1, 3 and 4 (each within the scatter of the next, the first and the last beyond it).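

Hydrogen in place of ethyl on a saturated chain carbon, nine bonds along the chain from a carbonyl carbon, gives the first step in the series beyond the scatter: a 2.6-fold higher number from compound 1 to compound 4 (0.41 log units; beyond the scatter) in this assay. The far end of the chain therefore registers in this assay, with the shorter chain giving the higher number in this single pair. No supporting measurement bears on the reason for this step.

As far as these compounds go, it remains open whether a longer chain would continue this trend in the opposite direction. Also open, from the compounds shown here alone, are whether the same shortening behaves alike with the added hydroxy of compound 2, and whether an amide in place of the ester would preserve the step.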